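The compounds below may be only part of what the source reports. "The series", "measured", "known", "first", "only" and "open" are said of these compounds alone.

Compound 2 `CNC(=O)C1CCCC1n1cnc2c(NCc3ccccc3)ncnc21` carries a benzyl group on the amine nitrogen of the shared core. In an assay on cell membranes for displacement of a labelled ligand from adenosine receptor A1 (Rattus norvegicus), tested at 100 uM (on this read-out higher numbers stand for more inhibition at the one concentration tested (going by the name of the read-out) and lower numbers for less inhibition), compound 2 gives 26%. Among the measured compounds shown here, its only comparison partner is compound 1 `CNC(=O)C1CCCC1n1cnc2c(N)ncnc21`, which bears a hydrogen in place of that benzyl; in this assay compound 1 gives 25%. The step of a number 1 percentage points higher from compound 1 to compound 2 (within the scatter) lies within the usual scatter, so the two numbers cannot be told apart, and compound 2 does not stand out from compound 1 on what has been measured.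

Compound 3 `CNC(=O)C1CCCC1n1cnc2c(NCc3ccccc3I)ncnc21` differs from compound 2 by iodo in place of hydrogen on an aromatic carbon. For the measured compounds named here, no measured step touches the benzyl ring itself: the one step available, from compound 1 to compound 2, concerns a different place and was within the scatter, so it offers no direction for this change. On that basis the step from compound 2 to compound 3 is expected to be small or absent, a number 2 percentage points higher from compound 2 to compound 3 (within the scatter), within the scatter. For compound 3 in this assay the estimate is 28%, with a range from 10% to 50%.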

Compound 3, a percentage reported as inhibition, at one concentration (the size of the read-out at that concentration, not a potency): < 10%
Compound 3 ended at the assay's limit; the forecaster's own chance of this, stated with the estimate: 0%; at least 18 percentage points between middle value and limit.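

The benzyl ring proves to be a place where a change can register, which the earlier pair could not show. In this assay, iodo in place of hydrogen on an aromatic carbon, ortho to a large group, gives a number at least 16 percentage points lower from compound 2 to compound 3 (beyond the scatter), so adding this single iodine atom moves the read-out beyond the scatter, while adding the plain benzyl group gave only a number 1 percentage points higher from compound 1 to compound 2 (within the scatter). The comparison with the unsubstituted amine agrees, with 2-iodobenzyl in place of hydrogen on the nitrogen giving a number at least 15 percentage points lower from compound 1 to compound 3 (beyond the scatter), and the true size of both steps stays unknown, as the value of compound 3 is a limit of the assay and not a number: the limit of < 10% in this assay, at which 1 of the 3 values shown sits.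

Going by these compounds, whether fluoro, chloro, methyl or methoxy at the same place on the ring would also lower the number, or whether this is particular to iodo, stays open. Also open is whether iodo on another carbon of that ring would give the same result, so the compounds shown tie this step to the 2-iodobenzyl group alone.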